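This account rests on a few compounds, and the source may have more. Where it says the series, first, only, none or still open, it means among the compounds named here.

Compound 1 `NCC(=O)NC[C@@H]1CCCc2cc(S(=O)(=O)c3cccc(F)c3)ccc21` gives 0.316 nM in an assay on isolated protein for displacement of a labelled ligand from 5-hydroxytryptamine receptor 6 (Homo sapiens); a lower number here means a stronger inhibitor, a higher number a weaker inhibitor. Compound 2 `CNCC(=O)NC[C@@H]1CCCc2cc(S(=O)(=O)c3cccc(F)c3)ccc21` gives 0.159 nM, and compound 3 `CS(=O)(=O)NC[C@@H]1CCCc2cc(S(=O)(=O)c3cccc(F)c3)ccc21` gives 0.2 nM. The cores of compound 1 and compound 3 differ by methylsulfonyl in place of (aminomethyl)carbonyl on an amine nitrogen, a step of a 1.6-fold lower number from compound 1 to compound 3 (0.20 log units; within the scatter); compound 2 and compound 3 differ by a 1.3-fold higher number from compound 2 to compound 3 (0.10 log units; within the scatter). Compound 4 `CN(C[C@@H]1CCCc2cc(S(=O)(=O)c3cccc(F)c3)ccc21)S(C)(=O)=O` remains to be measured. It differs from compound 3 by methyl in place of hydrogen on a sulfonamide nitrogen, the same kind of change as methyl in place of hydrogen on an amine nitrogen, which gave a 2.0-fold lower number from compound 1 to compound 2 (0.30 log units; within the scatter); here the place is a sulfonamide nitrogen whose other neighbours are a saturated chain carbon and a sulfonyl sulfur, rather than an amine nitrogen with a saturated chain carbon alone. Going by the values given here, with only one example of this kind of change, the step from compound 3 to compound 4 is expected to be a 1.6-fold higher number from compound 3 to compound 4 (0.20 log units; within the scatter). Compound 4 is estimated at 0.32 nM, between 0.1 nM and 1 nM.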

Compound 4, inhibition constant: 0.398 nM
Compound 4: the middle estimate sits 1.2-fold (0.09 log units) below what was measured; the measured number falls inside the stated range.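

Methyl in place of hydrogen on the sulfonamide nitrogen gives a 2.0-fold higher number from compound 3 to compound 4 (0.30 log units; within the scatter), while the wider steps give a 1.3-fold higher number from compound 1 to compound 4 (0.10 log units; within the scatter) and a 2.5-fold higher number from compound 2 to compound 4 (0.40 log units; beyond the scatter), and only the last of these lies beyond the scatter. In this assay, the methyl change does not carry from one core to the other with the same size and direction: the same change on two cores in this assay, a 2.0-fold lower number (0.30 log units; within the scatter) from compound 1 to compound 2 and a 2.0-fold higher number (0.30 log units; within the scatter) from compound 3 to compound 4, 4.0-fold (0.60 log units) apart, beyond the scatter of two such steps Each step alone lies within the scatter, however, and this single pair, on an amine nitrogen and a sulfonamide nitrogen, shows neither why the steps differ nor how the change would read on other cores.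

The compounds shown leave open whether an ethyl group or a longer chain on the sulfonamide nitrogen would read like the methyl. They also leave open how the methyl change reads when an acetyl group stands in place of the methylsulfonyl.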